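Exchanging One Aromatic Ring in Compound 2

The source may report more compounds than this note shows. Statements on the series, on what has been measured and on what is new or still open speak of the compounds shown alone.

In an ADME assay on the whole organism (strain Sprague-Dawley) for pharmacokinetics, with Rattus norvegicus as the target, using cassette dosing, at a dose of 1 mg/kg by the oral route (a higher number here means that a larger share of the oral dose reaches the circulation, a lower number that a smaller share of the oral dose reaches the circulation), compound 1 `O=c1[nH]c2ccc(-c3cc(C[C@]4(O)CC[C@@H](Cc5ccccc5)CC4)no3)cc2o1` gives 8.4%, compound 3 `O=c1ccc(-c2cc(C[C@]3(O)CC[C@@H](Cc4ccc(Cl)cc4)CC3)no2)c[nH]1` gives 37.2%, and compound 2 `O=c1ccc(-c2cc(C[C@]3(O)CC[C@@H](Cc4ccccc4)CC3)no2)c[nH]1` stands highest with 53.1%. Compound 4 `O[C@]1(Cc2cc(-c3cn[nH]c3)on2)CC[C@H](Cc2ccccc2)CC1` differs from compound 2 in one place: a group of 5 heavy atoms (3 carbon, 2 nitrogen; one five-membered aromatic ring with 2 hetero atoms) in place of a group of 7 heavy atoms (5 carbon, 1 nitrogen, 1 oxygen; one six-membered aromatic ring with 1 hetero atom), on an aromatic carbon. Among the measured compounds shown here, the closest precedent is an exchange at this same place, a number 44.7 percentage points higher from compound 1 to compound 2 (beyond the scatter), which is large, although it involves different groups. The chloro change, a number 15.9 percentage points lower from compound 2 to compound 3 (beyond the scatter), is modest and lies elsewhere in the molecule. Changes at this place can therefore matter greatly, but no measured compound carries 1H-pyrazol-4-yl. With the starting value already the highest of the three, the expected step is a number 13.1 percentage points lower from compound 2 to compound 4 (beyond the scatter), downward and modest. Compound 4 is expected at 40%, with an estimated range of 15% to 65%.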

Compound 4, oral bioavailability: 46.3%
For compound 4 the middle estimate is 6.3 percentage points below the measured one; low and high end bracket the measured number.
By their numbers in this assay, from the lowest: compound 1; then compounds 3, 4 and 2 (each within the scatter of the next, the first and the last beyond it).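

In this assay the exchange for 1H-pyrazol-4-yl (a number 6.8 percentage points lower from compound 2 to compound 4 (within the scatter)) shows that a five-membered aromatic ring with 2 hetero atoms can stand at this place without a shift beyond the scatter. Set against the larger two-ring group, the same 1H-pyrazol-4-yl gives a large step (a number 37.9 percentage points higher from compound 1 to compound 4 (beyond the scatter)), so a large rise at this place does not depend on the six-membered ring alone. Nothing given here explains either step. On these data alone, whether a ring is needed at this place stays open, and a simple amine or a carboxylic acid there could test it. Also open, as far as these compounds go, is whether chloro on the benzyl ring would lower compound 4 as it lowered compound 2.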